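A few compounds are considered here, and "the series" means these few. Any claim that something is new, unique, unknown or untested is made for them only; others in the source may bear on it.

Compound 2 `COc1ccc(N2CCN/C2=N\N)cc1` and compound 3 `COc1ccccc1N1CCn2c1n[nH]c(=O)c2=O` share no counted difference; how their two cores differ is not broken down here. In an ADME assay on Vero cells (Chlorocebus sabaeus) for cytotoxicity, with a stated time of 72 h, tested at 50 ug/mL (on this read-out higher numbers stand for a stronger effect at the one concentration tested and lower numbers for a weaker effect), compound 2 gives 0%, the lowest of the three numbers, while compound 3 gives 17% and compound 1 `O=c1[nH]nc2n(c1=O)CCN2c1ccccc1` gives 30%. Compound 3 and compound 1 differ only in one place, (hydrogen in place of methoxy on an aromatic carbon), and in this assay the step was a number 13 percentage points higher from compound 3 to compound 1 (beyond the scatter), a modest rise that lies beyond the scatter. Compound 4 `N/N=C1\NCCN1c1ccccc1` stands to compound 2 in the same kind of relation, (hydrogen in place of methoxy on an aromatic carbon), though the place is not the same: in compound 2 the methoxy sits para to a group of 7 heavy atoms, whereas in compound 3 it sits ortho to a large group. Resting on the step that compound 1 made over compound 3, the same kind of change from compound 2 is expected to give a number 10 percentage points higher from compound 2 to compound 4 (within the scatter) in this assay. Compound 4 is therefore estimated at 10%, with a range from 0% to 25%.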

Compound 4, a percentage reported as inhibition, at one concentration (the size of the read-out at that concentration, not a potency): 0%
Compound 4: the middle estimate sits 10 percentage points above what was measured; measured number inside the range.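

In this assay, hydrogen in place of methoxy on an aromatic carbon gives no change at the digits printed from compound 2 to compound 4 (within the scatter), whereas the same kind of change on the other core gave a number 13 percentage points higher from compound 3 to compound 1 (beyond the scatter). Set side by side, the two steps cannot be told apart: the same change on two cores in this assay, a number 13 percentage points higher (beyond the scatter) from compound 3 to compound 1 and no change at the digits printed (within the scatter) from compound 2 to compound 4, 13 percentage points apart, within the scatter of two such steps This shows that the pairs give no firm sign that the core alters the step, but it does not show that the step carries over unchanged, since only two pairs are at hand, one step lies beyond the scatter and the other within it, and the methoxy does not stand at the same place in the two pairs, so core and place cannot be separated.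

The compounds shown leave open how the same change would read with the methoxy at one shared place on both cores. They also leave open what a hydroxyl, an amine or a longer alkoxy chain on that aromatic carbon would give on either core.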